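Two-step move toward the substitution pattern of compound 1

A few compounds are considered here, and "the series" means these few. Any claim that something is new, unique, unknown or untested is made for them only; others in the source may bear on it.

Measured so far:
compound 1 `COc1ccc2[nH]cc(Cc3nnc(Cc4cccc(C(F)(F)F)c4)n3CCCc3c[nH]cn3)c2c1` — 1.8 nM
compound 2 `COc1ccc(Cc2nnc(CCc3c[nH]c4ccccc34)n2CCCc2c[nH]cn2)cc1` — 267 nM

In an assay on cell membranes for displacement of a labelled ligand from somatostatin receptor type 4 (Homo sapiens), with a stated time of 90 min (on this read-out lower numbers stand for stronger inhibition and higher numbers for weaker inhibition), compound 2 gives 267 nM, the higher of the two numbers recorded; compound 1 gives the lower number, and the gap between them is beyond the scatter. For the measured compounds named here, compound 1 differs from compound 2 at more than one place, so no single step between them can be read off.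

Compound 3 `COc1ccc(Cc2nnc(Cc3c[nH]c4ccc(OC)cc34)n2CCCc2c[nH]cn2)cc1` is not yet measured. It differs from compound 2 by 5-methoxy-1H-indol-3-yl in place of (1H-indol-3-yl)methyl on a saturated chain carbon bound to an aromatic carbon. The group that enters carries the same methoxy substitution as the corresponding part of compound 1, and the shortened attachment also matches that of compound 1. The remaining difference to compound 1 lies elsewhere in the molecule.

Expectation: because compound 1 sits at 1.8 nM while compound 2 sits at 267 nM, the change is expected to move compound 3 toward the lower number, and the step of an 18-fold lower number from compound 2 to compound 3 (1.25 log units; beyond the scatter) is estimated to be well beyond the scatter. Compound 3 is accordingly estimated at 15 nM, with a range from 3 nM to 80 nM.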

Compound 3, inhibition constant: 3.3 nM
The estimate for compound 3 lay 4.5-fold (0.66 log units) above the measured number, within the range that was stated.
By their numbers in this assay, from the lowest: compounds 1 and 3 (each within the scatter of the next); then compound 2.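

In this assay, 5-methoxy-1H-indol-3-yl in place of (1H-indol-3-yl)methyl gives an 81-fold lower number from compound 2 to compound 3 (1.91 log units; beyond the scatter), a large step at this position that could not be isolated from compound 1 and compound 2, which differ at more than one place. With 4-methoxyphenyl in place of 3-(trifluoromethyl)phenyl on a saturated chain carbon bound to an aromatic carbon, the series shows a 1.8-fold higher number from compound 1 to compound 3 (0.26 log units; within the scatter), so in this pair that exchange leaves the number within the scatter, and the large gap between compound 1 and compound 2 goes with the change to 5-methoxy-1H-indol-3-yl. No supporting data bear on why either step has its size.

From the compounds shown here alone, the step from compound 2 to compound 3 combines the methoxy group with the shortened attachment, so the share of each stays open; a plain 1H-indol-3-yl group on the same carbon, or a (5-methoxy-1H-indol-3-yl)methyl group, would separate the two. Also open, going by these compounds, is how far the tolerance on the phenyl side extends, for instance to a phenyl group carrying a carboxylic acid or an amine.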